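Formyl for methoxy at the aryl substituent: expectation for compound 3

The source may hold more compounds than are shown below. What is called first, only, known or untested is meant among the compounds shown, and "the series" means these compounds.

Measured so far in a functional assay on NCI-H226 cells (Homo sapiens) for inhibition, read by sulforhodamine B assay, with a stated time of 48 h, tested at 10 uM; a higher number here means more inhibition at the concentration tested (going by the name of the read-out), a lower number less inhibition:
compound 1 `Brc1cn2ccnc2c(-c2ccc3ncn(C4CCCCC4)c3c2)n1` gives 22.5%
compound 2 `COc1ccc(-c2cn3ccnc3c(-c3ccc4ncn(C5CCCCC5)c4c3)n2)cc1` gives 35.9%

Compound 2 stands highest of the two numbers; the step of a number 13.4 percentage points higher from compound 1 to compound 2 (beyond the scatter) is beyond the scatter. Compound 3 `O=Cc1ccc(-c2cn3ccnc3c(-c3ccc4ncn(C5CCCCC5)c4c3)n2)cc1` differs from compound 2 by formyl in place of methoxy on an aromatic carbon. Among the measured compounds shown here, no measured step exchanges one substituent on the 4-substituted phenyl for another; the only step known swaps bromo for the whole 4-methoxyphenyl. Both entering and leaving groups are counted as two heavy atoms with one acceptor, so no step beyond the scatter is expected. Compound 3 is estimated at 33% (range 19% to 47%), a step of a number 2.9 percentage points lower from compound 2 to compound 3 (within the scatter).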

Compound 3, a percentage reported as inhibition, at one concentration (the size of the read-out at that concentration, not a potency): 0.53%
Compound 3: middle estimate off by 32.5 percentage points, on the high side, outside the stated range (below it).
By their numbers in this assay, from the lowest: compound 3; then compound 1; then compound 2.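

In this assay, the substituent on the aromatic carbon of the aryl group matters even where the counted heavy atoms and acceptors stay the same: formyl in place of methoxy gives a number 35.4 percentage points lower from compound 2 to compound 3 (beyond the scatter) and takes the series to its lowest number. The gain over bromo is therefore not a general feature of a 4-substituted phenyl, since 4-formylphenyl in place of bromo gives a number 22 percentage points lower from compound 1 to compound 3 (beyond the scatter), against the rise seen with 4-methoxyphenyl. Nothing at hand explains this loss.

Open, as far as these compounds go, is how an amine or a carboxylic acid at this place would compare with methoxy and formyl. Also open, from the compounds shown here alone, is whether a longer alkoxy chain would hold or exceed the number of compound 2 35.9%.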